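Aryl Hydrazones Give Way to a Pentyl Chain

This account rests on a few compounds, and the source may have more. Where it says the series, first, only, none or still open, it means among the compounds named here.

Compound 1 `O=C(N/N=C/c1ccc(Cl)cc1)c1ccc(O[C@@H]2O[C@H](CO)[C@@H](O)[C@H](O)[C@H]2O)cc1`: 2.26%
Compound 2 `O=C(N/N=C/c1cccc([N+](=O)[O-])c1)c1ccc(O[C@@H]2O[C@H](CO)[C@@H](O)[C@H](O)[C@H]2O)cc1`: 6.23%
Compound 3 `Cc1ccc(/C=N/NC(=O)c2ccc(O[C@@H]3O[C@H](CO)[C@@H](O)[C@H](O)[C@H]3O)cc2)cc1`: 9.28%

In a functional assay on MDA-MB-231 cells (Homo sapiens) for inhibition, read by MTT assay, with a stated time of 24 h, tested at 100 uM (on this read-out higher numbers stand for more inhibition at the one concentration tested (going by the name of the read-out) and lower numbers for less inhibition), compound 1 gives 2.26%, compound 2 gives 6.23% and compound 3 gives 9.28%. Compound 3 carries the highest of the three numbers, yet both steps toward it, a number 7 percentage points higher from compound 1 to compound 3 (within the scatter) and a number 3.1 percentage points higher from compound 2 to compound 3 (within the scatter), lie within the scatter, so no order among the three can be read. Compound 4 `CCCCC/C=N/NC(=O)c1ccc(O[C@@H]2O[C@H](CO)[C@@H](O)[C@H](O)[C@H]2O)cc1` differs from compound 3 by pentyl in place of 4-methylphenyl on a carbon with a double bond to nitrogen. Among the compounds with values here, no measured step bears directly on this change: the steps so far, including a number 4 percentage points higher from compound 1 to compound 2 (within the scatter), only exchange one substituted phenyl for another and none leaves the scatter. Compound 4 is therefore estimated at 8%, within 0% to 20%. The expected step is a number 1.3 percentage points lower from compound 3 to compound 4 (within the scatter), expected to stay within the scatter.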

Compound 4, a percentage reported as inhibition, at one concentration (the size of the read-out at that concentration, not a potency): 11%
Compound 4: the middle estimate sits 3 percentage points below what was measured; the measured number falls inside the stated range.
By their numbers in this assay, from the lowest: compounds 1, 2, 3 and 4 (each within the scatter of the next).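

Within the data shown here, compound 4 is the first compound here with an open chain rather than a substituted phenyl on the carbon with a double bond to nitrogen, and this assay gives a number 1.7 percentage points higher from compound 3 to compound 4 (within the scatter) and a number 4.8 percentage points higher from compound 2 to compound 4 (within the scatter) and a number 8.7 percentage points higher from compound 1 to compound 4 (within the scatter) for this change. The aromatic ring is therefore not needed at this position for a number of this size, though no order among the four can be read. Nothing available explains these numbers.

Still open, on these data alone, is whether a longer chain, or a pentyl chain ending in an amine or a carboxylic acid, would move the number beyond the scatter.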